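This account rests on a few compounds, and the source may have more. Where it says the series, first, only, none or still open, it means among the compounds named here.

Working notes on the series. Among the compounds with values here, in a functional assay on the whole organism (strain Wister albino) for inhibition, with Rattus norvegicus as the target, read by paw edema, with stated times of 1 h and 3 h, at a dose of 50 mg/kg by the intraperitoneal route (on this read-out higher numbers stand for more inhibition at the one dose given (going by the name of the read-out) and lower numbers for less inhibition), compound 1 `CN1C[C@@H](c2ccccc2)[C@@]2(Cc3ccccc3C2=O)[C@@]12C(=O)Nc1ccccc12` gives 42.5% and compound 2 `CN1C[C@@H](c2cccs2)[C@@]2(Cc3ccccc3C2=O)[C@@]12C(=O)Nc1ccccc12` gives 32.6%; the single measured step, a number 9.9 percentage points lower from compound 1 to compound 2 (within the scatter), stays within the scatter. Compound 2 sits at the bottom of the two numbers shown, but compound 1 lies within the scatter of it, so no order between them is claimed. Compound 3 `CN1C(=O)[C@@]2(c3ccccc31)N(C)C[C@@H](c1cccs1)[C@@]21Cc2ccccc2C1=O` differs from compound 2 by methyl in place of hydrogen on an amide-type nitrogen in a ring. Within the data shown here, no measured step touches this amide-type nitrogen, so the aryl swap does not bear on it, and no change beyond the scatter is expected in this assay. In this assay compound 3 is expected at 32%, with a range from 18% to 46%. The expected step is a number 0.6 percentage points lower from compound 2 to compound 3 (within the scatter).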

Compound 3, a percentage reported as inhibition, in the whole organism at one dose (the size of the read-out at that dose, not a potency): 9.1%
Beside the measured number, compound 3's estimate is 22.9 percentage points above it; the measured number lies below the stated range.
By their numbers in this assay, from the lowest: compound 3; then compounds 2 and 1 (each within the scatter of the next).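

In this assay the step of a number 23.5 percentage points lower from compound 2 to compound 3 (beyond the scatter) shows that the amide-type nitrogen, which the earlier aryl swap left untouched, does bear on the read-out. Here, with thiophen-2-yl on the saturated ring carbon, methyl does not stand in for the amide hydrogen without loss. Nothing at hand gives a reason for this step.

From the compounds shown here alone, whether the same change on the phenyl compound 1 gives a step of similar size stays open. So does the outcome with ethyl, a longer chain or an acetyl group on this nitrogen.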